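From Azole to Carbamoyl on a Shared Core

The source may hold more compounds than are shown below. What is called first, only, known or untested is meant among the compounds shown, and "the series" means these compounds.

Compound 1, `CC(C)C(Cc1ncc[nH]1)c1ccc(-c2ccc3cccc(F)c3c2)[nH]c1=O`, gives 76 nM in a functional assay on CHO cells for antagonist activity at prostaglandin E2 receptor EP3 subtype (Homo sapiens), read by cAMP accumulation; on this read-out lower numbers stand for stronger inhibition and higher numbers for weaker inhibition. Compound 2, `CC(C)C(Cc1nnn[nH]1)c1ccc(-c2ccc3cccc(F)c3c2)[nH]c1=O`, gives 134 nM.

Among the two measured compounds, compound 2 has the highest number; its nearest neighbour is compound 1, and the step of a 1.8-fold higher number from compound 1 to compound 2 (0.25 log units; within the scatter) lies within the scatter, so the two cannot be ordered. Compound 3, `CC(C)C(CC(N)=O)c1ccc(-c2ccc3cccc(F)c3c2)[nH]c1=O`, is the unmeasured compound; it differs from compound 2 by carbamoyl in place of 1H-tetrazol-5-yl on a saturated chain carbon, two bonds along the chain from an aromatic carbon. Among the measured compounds shown here, only one measured step bears on this place on the chain, and it shows that one five-membered azole can stand in for another there with no change beyond the scatter. Whether a group with no ring is tolerated as well is not shown by these two compounds. Compound 3 is therefore expected to show a modest rise in number, a 1.9-fold higher number from compound 2 to compound 3 (0.27 log units; within the scatter), with wide uncertainty. The estimate for compound 3 is 250 nM, with a range of 80 nM to 800 nM.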

Compound 3, half-maximal inhibitory concentration: 53 nM
The estimate for compound 3 lay 4.7-fold (0.67 log units) above the measured number; the whole stated range lies above it.
By their numbers in this assay, from the lowest: compounds 3, 1 and 2 (each within the scatter of the next, the first and the last beyond it).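

At this place, on a saturated chain carbon, two bonds along the chain from an aromatic carbon, an aromatic ring is not needed for activity in this assay: carbamoyl, which has no ring and only 3 heavy atoms, gives a 2.5-fold lower number from compound 2 to compound 3 (0.40 log units; beyond the scatter) and so improves on 1H-tetrazol-5-yl by a step beyond the scatter. Against 1H-imidazol-2-yl the same group gives a 1.4-fold lower number from compound 1 to compound 3 (0.16 log units; within the scatter) and, with that step within the scatter, the two cannot be ordered, so the open-chain group matches one azole and surpasses the other. Nothing available explains this difference between the groups.

On these data alone, whether a carboxylic acid, a primary amine or a longer chain ending in carbamoyl would be tolerated at this place remains open. So does whether an N-methyl amide would keep the number seen with carbamoyl.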